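The compounds below may be only part of what the source reports. "The series", "measured", "known", "first", "only" and "open" are said of these compounds alone.

Measured compounds:
Compound 1 `COc1cccc2c1c(NS(=O)(=O)c1ccc(Cl)s1)nn2Cc1cccc(CNC(=O)C2COC2)c1`: 20 nM
Compound 2 `COc1cccc2c1c(NS(=O)(=O)c1ccc(Cl)s1)nn2Cc1cc(CNC(C)=O)ccn1`: 158 nM

Of the compounds shown here, two that share one core have been tested in a functional assay on CHO cells for antagonist activity at C-C chemokine receptor type 4 (Homo sapiens), read by GTPgammaS binding; a lower number here means a stronger inhibitor, a higher number a weaker inhibitor. Compound 1 gives 20 nM, while compound 2 gives 158 nM, the higher of the two numbers, and the gap between them lies beyond the usual scatter. Compound 3 `COc1cccc2c1c(NS(=O)(=O)c1ccc(Cl)s1)nn2Cc1ccnc(CNC(C)=O)c1` has not yet been measured. It is built from the same atoms as compound 2, joined differently: 2-(acetamidomethyl)pyridin-4-yl in place of 4-(acetamidomethyl)pyridin-2-yl on a saturated chain carbon bound to an aromatic nitrogen. No step between two measured compounds differing in a single place is available, so this rearrangement has no precedent among the compounds shown, and the weight of the wider change from compound 1 to compound 2 cannot be split into parts. The step from compound 2 to compound 3 is therefore expected to be modest, a 1.2-fold lower number from compound 2 to compound 3 (0.08 log units; within the scatter), in either direction or none beyond the scatter. Compound 3 is expected to give about 130 nM, within a range from 40 nM to 400 nM.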

Compound 3, half-maximal inhibitory concentration in the C-C chemokine receptor type 4 assay: 100 nM
Compound 3: the middle estimate sits 1.3-fold (0.11 log units) above what was measured, and the stated range covers the measured number.
By their numbers in the C-C chemokine receptor type 4 assay, from the lowest: compound 1; then compounds 3 and 2 (each within the scatter of the next).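

In the C-C chemokine receptor type 4 assay, placing 2-(acetamidomethyl)pyridin-4-yl in place of 4-(acetamidomethyl)pyridin-2-yl on a saturated chain carbon bound to an aromatic nitrogen gives a 1.6-fold lower number from compound 2 to compound 3 (0.20 log units; within the scatter). Among the compounds shown here, this is the first comparison here that changes one place only, and it shows that this rearrangement of the same atoms leaves the number within the scatter, so neither arrangement stands apart. In a physicochemical assay for acid dissociation, compound 2 gives "not determined" (no result reported) and compound 3 gives "not determined" (no result reported), so that read-out offers no comparison, and no other data here bear on this result.

Compound 1 differs from compound 2 and compound 3 in more than one place, so its gap to them cannot be divided among its changes. Going by these compounds, whether a carboxylic acid or a primary amine in place of the acetamide would also leave the number within the scatter remains open.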